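From 3,4-dimethylphenyl to 3-cyanophenyl: estimating compound 3

The source may report more compounds than this note shows. Statements on the series, on what has been measured and on what is new or still open speak of the compounds shown alone.

- Compound 1 `COc1cc(-c2ccnc3cc(-c4ccc(C)cc4)nn23)cc(OC)c1OC`: 47 nM
- Compound 2 `COc1cc(-c2ccnc3cc(-c4ccc(C)c(C)c4)nn23)cc(OC)c1OC`: 26 nM

Both values come from a functional assay on MCF7 cells (Homo sapiens) for inhibition, read by CCK-8 assay, with a stated time of 48 h (a lower number here means a stronger inhibitor, a higher number a weaker inhibitor), where compound 2 cannot be ranked against compound 1. Within the data shown here, the only measured step between them, a swap of methyl for hydrogen on an aromatic carbon, is small: a 1.8-fold lower number from compound 1 to compound 2 (0.26 log units; within the scatter).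

The unmeasured compound 3 `COc1cc(-c2ccnc3cc(-c4cccc(C#N)c4)nn23)cc(OC)c1OC` has 3-cyanophenyl in place of 3,4-dimethylphenyl on an aromatic carbon. Among the measured compounds shown here, it keeps neither methyl group, and no measured compound carries a nitrile, so the methyl step offers only weak guidance. A modest move towards a higher, weaker number is expected, with wide uncertainty. The expected change in this assay is a 3.1-fold higher number from compound 2 to compound 3 (0.49 log units; beyond the scatter), an estimate and not a measurement. For compound 3 the estimated value is 80 nM, with an expected range from 25 nM to 260 nM.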

Compound 3, half-maximal inhibitory concentration: > 10000 nM
Compound 3: a limit, no number; the forecaster's own chance of this, stated with the estimate: 3%; middle value at least 120-fold (2.09 log units) away from the limit.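

In this assay, the result for compound 3 is a limit of the assay and not a number: the limit of > 10000 nM in this assay, at which 1 of the 3 values shown sits.

Placing 3-cyanophenyl on this aromatic carbon of the five-membered ring gives an at least 380-fold higher number from compound 2 to compound 3 (2.58 log units; beyond the scatter), and set against the 4-methylphenyl group it gives an at least 210-fold higher number from compound 1 to compound 3 (2.32 log units; beyond the scatter). Among these compounds, the methyl step between the earlier compounds stayed within the scatter, so only now is it clear that this position is highly sensitive to what it carries, even when the entering and leaving groups have the same number of heavy atoms.

The compounds shown cannot separate the effect of adding the nitrile from that of losing the methyl groups. As far as these compounds go, it also stays open how an amine, a carboxylic acid or a longer alkyl chain would fare in this place.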